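The source may report more compounds than this note shows. Statements on the series, on what has been measured and on what is new or still open speak of the compounds shown alone.

In an ADME assay on MT4 cells (Homo sapiens) for cytotoxicity, read by MTT assay, with a stated time of 5 days (a lower number here means that less compound is tolerated, a higher number that more compound is tolerated), compound 1 (`Cc1cc(/C=C/C#N)cc(C)c1Oc1cc(NCCN(C)C)nc(Nc2ccc(C#N)cc2)c1`) gives 4270 nM and compound 2 (`Cc1cc(/C=C/C#N)cc(C)c1Oc1cc(NCC2CCCO2)nc(Nc2ccc(C#N)cc2)c1`) gives 73600 nM, the higher of the two numbers. Compound 3 (`Cc1cc(/C=C/C#N)cc(C)c1Oc1cc(Cl)nc(Nc2ccc(C#N)cc2)c1`) has not yet been measured. It carries chloro in place of ((oxolan-2-yl)methyl)amino on an aromatic carbon. Among the compounds with values here, only one measured step bears on this, a 17-fold higher number from compound 1 to compound 2 (1.24 log units; beyond the scatter), a large change within the chain that compound 3 loses. The direction of the change is uncertain. The expected step is therefore a moderate move towards a lower number, estimated as a 3.3-fold lower number from compound 2 to compound 3 (0.52 log units; beyond the scatter). Compound 3 is expected at 22000 nM, with an estimated range from 5000 nM to 100000 nM.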

Compound 3, half-maximal cytotoxic concentration: > 311000 nM
Compound 3: a limit, no number; the forecaster's own chance of this, stated with the estimate: 20%; at least 14-fold (1.15 log units) between middle value and limit.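

Compound 3 alone among the three stands at a limit rather than a number: the limit of > 311000 nM in this assay, at which 1 of the 3 values shown sits. In this assay, chloro in place of either amino chain on this aromatic carbon, next to the ring nitrogen, gives a higher number in both steps: an at least 4.2-fold higher number from compound 2 to compound 3 (0.62 log units; beyond the scatter) and an at least 72-fold higher number from compound 1 to compound 3 (1.86 log units; beyond the scatter). The earlier pair showed only that the end of the chain matters, whereas these steps place both chains below chloro.

Going by these compounds, the true size of both steps stays open with a limit in place of a value. Also open, on these data alone, is whether a bare amino group or a methoxy group on this carbon would fall with chloro or with the chains.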